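Heptyl for methoxy on the side chain of compound 1

A few compounds are considered here, and "the series" means these few. Any claim that something is new, unique, unknown or untested is made for them only; others in the source may bear on it.

Compound 1 `COC[C@H](C(C)C)C(c1ccc(O)c(OC)c1)c1ccc(O)c(OC)c1` gives 72000 nM in a functional assay on HL-60 cells (Homo sapiens) for cytotoxicity, read by WST assay, with a stated time of 48 h (a lower number here means a stronger inhibitor, a higher number a weaker inhibitor), the second highest of the three numbers measured. Compound 2 `COc1cc(C(c2ccc(O)c(OC)c2)[C@@H](CF)C(C)C)ccc1O` gives 39000 nM and compound 3 `COC[C@@H](C)[C@@H](C)C(c1ccc(O)c(OC)c1)c1ccc(O)c(OC)c1` gives 85000 nM. The step of a 1.8-fold lower number from compound 1 to compound 2 (0.27 log units; within the scatter) and the step of a 1.2-fold higher number from compound 1 to compound 3 (0.07 log units; within the scatter) both stay within the scatter; only a 2.2-fold higher number from compound 2 to compound 3 (0.34 log units; beyond the scatter) reaches beyond it, and modestly. Compound 4 `CCCCCCCC[C@H](C(C)C)C(c1ccc(O)c(OC)c1)c1ccc(O)c(OC)c1` differs from compound 1 by heptyl in place of methoxy on a saturated chain carbon, three bonds along the chain from two aromatic carbons. Going by the values given here, no measured step exchanges a methoxy for an alkyl chain, so none bears directly on this change; the nearest precedent, the exchange in a 1.8-fold lower number from compound 1 to compound 2 (0.27 log units; within the scatter), was small. The change is therefore expected to give at most a small step, a 1.3-fold lower number from compound 1 to compound 4 (0.12 log units; within the scatter). Compound 4 is estimated at 55000 nM, in the range 20000 nM to 150000 nM.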

Compound 4, half-maximal inhibitory concentration: 3700 nM
Compound 4: the middle estimate sits 15-fold (1.17 log units) above what was measured; measured number below the stated range.
By their numbers in this assay, from the lowest: compound 4; then compounds 2, 1 and 3 (each within the scatter of the next, the first and the last beyond it).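

Heptyl in place of methoxy gives a 19-fold lower number from compound 1 to compound 4 (1.29 log units; beyond the scatter) in this assay, so this position can carry a large change in the number, which the small or modest steps among compound 1, compound 2 and compound 3 did not reveal. The side chain also accepts the heptyl without loss in this read-out. No measurement shown accounts for the step.

Still open, as far as these compounds go, is whether the step follows chain length or the removal of the ether oxygen. Ethyl, a longer chain than heptyl, or a terminal amine at the same place would separate these readings.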